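This account rests on a few compounds, and the source may have more. Where it says the series, first, only, none or still open, it means among the compounds named here.

Compound 3 `CCCN(CCC)CCCCOc1ccccc1/C=C/c1ccccc1` has the lowest number of the three compounds measured in a functional assay on the whole organism with Mus musculus as the target, in the maximal electroshock model, at a dose of 50 mg/kg by the oral route; on this read-out lower numbers stand for less inhibition and higher numbers for more inhibition at the one dose given (going by the name of the read-out): compound 3 gives 0%, the lowest of the three numbers. Its nearest neighbour is compound 1 `CN(C)CCCOc1ccccc1/C=C/c1ccccc1`, which in this assay gives 14.2%, and the furthest is compound 2 `CN(C)CCCCOc1ccccc1/C=C/c1ccccc1Cl`, which gives 14.3%. Within the data shown here, the only step that connects measured compounds in one place is the one a number 14.2 percentage points lower from compound 1 to compound 3 (beyond the scatter), so replacing dimethylamino with dipropylamino on the chain cost a modest but real share of the inhibition.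

The next compound, compound 4 `C(=C/c1ccccc1OCCCCN1CCCC1)\c1ccccc1`, differs from compound 3 as follows: pyrrolidin-1-yl in place of dipropylamino on a saturated chain carbon, four bonds along the chain from an oxygen on an aromatic ring. This change bears on the same part of the molecule as the step from compound 1 to compound 3, but it moves the other way, from the larger dipropylamino back toward a smaller amine, here a five-membered ring. Compound 1 and compound 2, both carrying dimethylamino, sit close together near the level of compound 1, so a return toward such an amine is expected to recover part of that loss. The step of a number 10 percentage points higher from compound 3 to compound 4 (within the scatter) is therefore expected to be a modest rise. For compound 4 an estimate of 10% is given, expected to lie between 0% and 28%.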

Compound 4, a percentage reported as inhibition, in the whole organism at one dose (the size of the read-out at that dose, not a potency): 42.9%
Beside the measured number, compound 4's estimate is 32.9 percentage points below it; measured number above the stated range.
By their numbers in this assay, from the lowest: compound 3; then compounds 1 and 2 (each within the scatter of the next); then compound 4.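

In this assay, the amine at the end of the chain turns out to be a place where activity can be gained as well as lost: with pyrrolidin-1-yl in place of dipropylamino, four bonds along the chain from an oxygen on an aromatic ring, there is a number 42.9 percentage points higher from compound 3 to compound 4 (beyond the scatter). The ring also does more than return the compound to the level of a dimethylamino compound, since there is a number 28.7 percentage points higher from compound 1 to compound 4 (beyond the scatter), although this second step, read as (pyrrolidin-1-yl)methyl in place of dimethylamino, changes the chain as well as the amine. Nothing available here accounts for the size of this rise.

As far as these compounds go, it remains open whether the gain belongs to pyrrolidin-1-yl in particular or would also be seen with piperidin-1-yl, morpholin-4-yl or diethylamino at the same place. From the compounds shown here alone, it is equally open whether pyrrolidin-1-yl would keep this level on the shorter chain of compound 1, on a longer chain, or together with the chloro group of compound 2.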